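Ester acyl swap, cytotoxicity working notes

The source may report more compounds than this note shows. Statements on the series, on what has been measured and on what is new or still open speak of the compounds shown alone.

Going by the values given here, compound 2 `O=C(OCCc1c(-c2ccccc2Cl)c2cc(Cl)ccc2[nH]c1=O)C1CCCC1` gives 46000 nM in an ADME assay on HepG2 2.2.15 cells (Homo sapiens) for cytotoxicity (on this read-out lower numbers stand for higher toxicity in this test and higher numbers for lower toxicity in this test), the lowest of the two numbers so far; compound 1 `O=CCc1c(-c2ccccc2Cl)c2cc(Cl)ccc2[nH]c1=O` gives 120000 nM. Among the compounds with values here, the one measured step, a 2.6-fold lower number from compound 1 to compound 2 (0.42 log units; beyond the scatter), concerns the exchange of the formyl group for the ester and says nothing about the acyl part of that ester. Compound 3 `C/C=C/C(=O)OCCc1c(-c2ccccc2Cl)c2cc(Cl)ccc2[nH]c1=O` differs from compound 2 by prop-1-en-1-yl in place of cyclopentyl on a carbonyl carbon. Within the data shown here, no measured step bears on this exchange, so no step beyond the scatter is expected in this assay. The estimate for compound 3 is 50000 nM (range 25000 nM to 100000 nM), an expected step of a 1.1-fold higher number from compound 2 to compound 3 (0.04 log units; within the scatter).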

Compound 3, half-maximal cytotoxic concentration: 30000 nM
Compound 3: the middle estimate sits 1.7-fold (0.22 log units) above what was measured; measured number inside the range.
By their numbers in this assay, from the lowest: compounds 3 and 2 (each within the scatter of the next); then compound 1.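

In this assay the exchange of cyclopentyl for prop-1-en-1-yl on a carbonyl carbon gives a 1.5-fold lower number from compound 2 to compound 3 (0.19 log units; within the scatter) and so shows that the ring can go and a double bond can enter at this position without a step beyond the scatter. With a second acyl group, the exchange of formyl for the ester again gives a modest change, a 4.0-fold lower number from compound 1 to compound 3 (0.60 log units; beyond the scatter) and in the same direction as a 2.6-fold lower number from compound 1 to compound 2 (0.42 log units; beyond the scatter) so the earlier step no longer rests on a single ester. No available evidence accounts for these results.

As far as these compounds go, an acyl group carrying an amine or a carboxylic acid remains open, as does a longer chain in place of prop-1-en-1-yl. With only two esters shown, how far this position can shift the cytotoxicity read-out is also unsettled.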